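Swapping Benzyloxy for tert-Butyl on the Sulfonyl Aryl Ring

This account rests on a few compounds, and the source may have more. Where it says the series, first, only, none or still open, it means among the compounds named here.

Going by the values given here, compound 1, `CC1CCN(C2CCN(S(=O)(=O)c3ccc(OCc4ccccc4)cc3)CC2)CC1`, stands lowest of the two numbers measured so far. In a functional assay on DLD-1 cells (Homo sapiens) for antiproliferative activity, read by CellTiter-Glo, with a stated time of 72 h (on this read-out higher numbers stand for weaker inhibition and lower numbers for stronger inhibition), compound 1 gives 385 nM. Compound 2, `COc1ccc(-c2ccccc2S(=O)(=O)N2CCC(N3CCC(C)CC3)CC2)cc1`, is built on the same core with a different decoration, and in this assay compound 2 gives 1000 nM, a difference from compound 1 that lies beyond the usual scatter. Compound 3, `CC1CCN(C2CCN(S(=O)(=O)c3ccc(C(C)(C)C)cc3)CC2)CC1`, keeps the core of compound 1 and changes one thing: tert-butyl in place of benzyloxy on an aromatic carbon. Among the compounds with values here, no measured pair shows this exchange, so the two values in hand say nothing direct about its size. The group that leaves is larger than the one that enters, and it takes an acceptor with it. The expected outcome is a step of a 1.7-fold higher number from compound 1 to compound 3 (0.23 log units; within the scatter), a modest weakening that could still fall within the scatter. Compound 3 is therefore estimated at 650 nM, with a likely range from 200 nM to 2200 nM.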

Compound 3, half-maximal inhibitory concentration: > 5000 nM
Compound 3 was reported as a limit; the forecaster's own chance of this, stated with the estimate: 5%; at least 7.6-fold (0.88 log units) between middle value and limit.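

On this aromatic carbon, the exchange of benzyloxy for tert-butyl is far from a minor adjustment: in this assay it gives an at least 12-fold higher number from compound 1 to compound 3 (1.11 log units; beyond the scatter). The result for compound 3 is a limit of the assay and not a number, and the step has to be read with that in mind: the limit of > 5000 nM in this assay, at which 1 of the 3 values shown sits. This single exchange shows that the group on this carbon weighs heavily on the read-out, and that tert-butyl cannot stand in for benzyloxy here.

The exchange removes the oxygen and the outer aromatic ring together, and the compounds shown cannot say which of the two loss matters, or whether both do. A benzylamino group on the same carbon, or a plain alkyl chain ending in a phenyl ring, would help pull these apart.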